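Nitro for trifluoromethyl on the benzyl ether of compound 1

A few compounds are considered here, and "the series" means these few. Any claim that something is new, unique, unknown or untested is made for them only; others in the source may bear on it.

Compound 1 `FC(F)(F)c1ccc(COc2cccc(Nc3ncnc4cc5c(cc34)OCCOCCO5)c2)cc1` gives only a limit in a functional assay on HepG2 cells (Homo sapiens) for antiproliferative activity, read by MTT assay, with a stated time of 72 h; a lower number here means a stronger inhibitor, a higher number a weaker inhibitor: compound 1 reports > 100000 nM. Compound 3 `FC(F)(F)c1ccc(COc2ccccc2Nc2ncnc3cc4c(cc23)OCCOCCOCCO4)cc1` likewise sits at a limit, with > 100000 nM. Compound 2 `c1ccc(COc2ccccc2Nc2ncnc3cc4c(cc23)OCCOCCOCCO4)cc1` gives 37300 nM in this assay. Within the data shown here, the one measured step, an at least 2.6-fold higher number from compound 2 to compound 3 (0.42 log units; beyond the scatter), concerns trifluoromethyl in place of hydrogen and is not the change at hand. Compound 4 `O=[N+]([O-])c1ccc(COc2cccc(Nc3ncnc4cc5c(cc34)OCCOCCO5)c2)cc1` differs from compound 1 by nitro in place of trifluoromethyl on an aromatic carbon. Among the measured compounds shown here, no measured pair shows nitro replacing trifluoromethyl, so the size of this step cannot be read from the series; two of the three values shown sit at the limit of > 100000 nM in this assay, at which 2 of the 3 values shown sit. The expected step is a number no higher from compound 1 to compound 4 (the limit leaves the size open), that is no clear movement. Compound 4 is therefore estimated at 100000 nM, within 30000 nM to 300000 nM, most likely reported again only as a limit.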

Compound 4, half-maximal inhibitory concentration: 65300 nM
Compound 4: middle estimate off by 1.5-fold (0.19 log units), on the high side; low and high end bracket the measured number.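

In this assay, nitro at this place on the benzyl ether gives a measured number and not only a limit, with an at least 1.5-fold lower number from compound 1 to compound 4 (0.18 log units; that floor lies within the scatter). Compound 1 remains a limit, so the true size of this step stays unfixed and no gain can be claimed for nitro over trifluoromethyl: the limit of > 100000 nM in this assay, at which 2 of the 4 values shown sit.

Open, as far as these compounds go, is how an amine or a carboxylic acid at this same place on the aromatic ring would read. Also open, from the compounds shown here alone, is how nitro compares with hydrogen on the core of compound 1.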